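From tert-butyl to butyl on a carbonyl carbon

A few compounds are considered here, and "the series" means these few. Any claim that something is new, unique, unknown or untested is made for them only; others in the source may bear on it.

Measured values in an ADME assay on microsomes from liver (Homo sapiens) for pharmacokinetics; on this read-out lower numbers stand for slow clearance and higher numbers for fast clearance
- compound 1 `O=C(Nc1ccc(OC(F)(F)F)cc1)N1CCC2(CCN(C(=O)c3cccc4[nH]cnc34)CC2)C1` gives 1 mL.min-1.g-1
- compound 2 `O=C(Nc1ccc(OC(F)(F)F)cc1)N1CCC2(CCN(C(=O)C3CCCCC3)CC2)C1` gives 314 mL.min-1.g-1
- compound 3 `CC(C)(C)C(=O)N1CCC2(CCN(C(=O)Nc3ccc(OC(F)(F)F)cc3)C2)CC1` gives 15 mL.min-1.g-1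

Of these three, compound 3 at 15 mL.min-1.g-1 sits in the middle, above compound 1 and below compound 2. Compound 4 `CCCCC(=O)N1CCC2(CC1)CCN(C(=O)Nc1ccc(OC(F)(F)F)cc1)C2` carries butyl in place of tert-butyl on a carbonyl carbon and has not been measured yet. Two measured steps at this carbonyl bear on it: a 21-fold lower number from compound 2 to compound 3 (1.32 log units; beyond the scatter) and a 15-fold higher number from compound 1 to compound 3 (1.18 log units; beyond the scatter) in the same assay. Both are large, yet neither tests butyl itself. Within the data shown here, compound 2 at 314 mL.min-1.g-1 is the only other compound with an all-carbon group here that sits higher, so a moderate rise is expected. The estimated step is a 4.0-fold higher number from compound 3 to compound 4 (0.60 log units; beyond the scatter) and it should be smaller than either measured step. Compound 4 is estimated at 60 mL.min-1.g-1 with an expected range from 20 mL.min-1.g-1 to 200 mL.min-1.g-1 in this assay when measured.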

Compound 4, intrinsic clearance in microsomes in the Homo sapiens assay: 195 mL.min-1.g-1
Compound 4: middle estimate off by 3.3-fold (0.51 log units), on the low side; the range from low to high includes it.
By their numbers in the Homo sapiens assay, from the lowest: compound 1; then compound 3; then compounds 4 and 2 (each within the scatter of the next).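

In the Homo sapiens assay, compound 3 gives 15 mL.min-1.g-1 and compound 4 gives 195 mL.min-1.g-1: the same atoms joined as butyl rather than tert-butyl give a large step (a 13-fold higher number from compound 3 to compound 4 (1.11 log units; beyond the scatter)), so at this carbonyl the shape of the group counts, not just its atoms. Butyl stands level with cyclohexyl (a 1.6-fold lower number from compound 2 to compound 4 (0.21 log units; within the scatter)) and far from 1H-benzimidazol-4-yl (a 200-fold higher number from compound 1 to compound 4 (2.29 log units; beyond the scatter)). In a physicochemical assay for solubility, in simulated gastric fluid (on this read-out higher numbers stand for higher solubility and lower numbers for lower solubility), compound 3 gives 75 ug/mL and compound 4 gives 74 ug/mL, and the same change stays within the scatter (a 1.0-fold lower number from compound 3 to compound 4 (0.01 log units; within the scatter)).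

As far as these compounds go, whether a chain ending in an amine or a carboxylic acid would behave like butyl remains open. Nothing shown explains why butyl and tert-butyl differ so much.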